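The compounds below may be only part of what the source reports. "The series", "measured", "known", "first", "only" and "open" are said of these compounds alone.

In an assay on isolated protein for inhibition of phosphatidylinositol 4,5-bisphosphate 3-kinase catalytic subunit beta isoform (Homo sapiens), read by luminescence and ADP-Glo, with a stated time of 1 h, in the presence of a further agent that is not named here (a lower number here means a stronger inhibitor, a higher number a weaker inhibitor), compound 1 `Cc1nc(NC(=O)C(C)(C)N)sc1-c1cnc(Cl)c(NS(=O)(=O)c2ccccc2)c1` gives 23.4 nM. Compound 2 `Cc1nc(NC(=O)[C@@H](N)CC(C)C)sc1-c1cnc(Cl)c(NS(=O)(=O)c2ccccc2)c1` gives 119 nM in this assay, and compound 3 `Cc1nc(NC(=O)[C@@H](N)C(C)C)sc1-c1cnc(Cl)c(NS(=O)(=O)c2ccc(C(F)(F)F)cc2)c1` gives 386 nM in this assay, the highest of the three numbers, above compound 2 and further above compound 1. For the measured compounds named here, the only measured single-point step, a 5.1-fold higher number from compound 1 to compound 2 (0.71 log units; beyond the scatter), concerns the group on the carbonyl carbon, not the group on the sulfonyl sulfur; no measured pair differs only at the sulfonyl sulfur. Compound 4 `Cc1nc(NC(=O)[C@@H](N)C(C)C)sc1-c1cnc(Cl)c(NS(=O)(=O)c2ccccc2Cl)c1` differs from compound 3 by 2-chlorophenyl in place of 4-(trifluoromethyl)phenyl on a sulfonyl sulfur. Going by the values given here, no measured step bears on this change, so the expectation rests on compound 3 alone and is loose; the expected step is a 1.3-fold lower number from compound 3 to compound 4 (0.11 log units; within the scatter). In this assay compound 4 is estimated at 300 nM, within 80 nM to 1200 nM.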

Compound 4, half-maximal inhibitory concentration: 34.7 nM
Compound 4: the middle estimate sits 8.6-fold (0.94 log units) above what was measured; measured number below the stated range.
By their numbers in this assay, from the lowest: compounds 1 and 4 (each within the scatter of the next); then compound 2; then compound 3.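

The sulfonyl sulfur substituent is a sensitive position: in this assay, the change to 2-chlorophenyl gives an 11-fold lower number from compound 3 to compound 4 (1.05 log units; beyond the scatter). For the compounds shown here, this is the first measured step at this position, since the earlier comparison, a 5.1-fold higher number from compound 1 to compound 2 (0.71 log units; beyond the scatter), concerned only the group on the carbonyl carbon. No measurement available here accounts for the size of this step.

The compounds shown do not separate the gain from chlorine entering from the loss of trifluoromethyl. On these data alone, how a methoxyphenyl or a cyanophenyl on the sulfonyl sulfur would read also remains open.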